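This account rests on a few compounds, and the source may have more. Where it says the series, first, only, none or still open, it means among the compounds named here.

Going by the values given here, compound 1, with structure `CCNC(=O)c1cc(Oc2ccc(NC(=O)c3nn(-c4cccc(F)c4)c(=O)cc3C)cc2)ccn1`, is the stronger of the two compounds measured so far in a functional assay on HeLa cells (Homo sapiens) for antiproliferative activity, read by MTT assay, with a stated time of 72 h; a lower number here means a stronger inhibitor, a higher number a weaker inhibitor. In this assay compound 1 gives 6870 nM. Compound 2, with structure `CCCNC(=O)c1cc(Oc2ccc(NC(=O)c3nn(-c4ccc(Br)cc4F)c(=O)cc3C)cc2F)ccn1`, gives 53500 nM in this assay, a markedly higher number than that of compound 1, and the two values lie well apart, beyond the usual scatter. Compound 2 differs from compound 1 in several places at once, so no single step can be read from the pair.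

Compound 3, with structure `CCNC(=O)c1cc(Oc2ccc(NC(=O)c3nn(-c4cccc(C(F)(F)F)c4)c(=O)cc3C)cc2)ccn1`, differs from compound 1 in exactly one place: trifluoromethyl in place of fluoro on an aromatic carbon. The change is confined to a single position on a six-membered aromatic ring of carbon only, meta to a large group, and nothing in the measured pair speaks to what it will do. Among the compounds with values here, with no step between measured compounds to lean on, compound 3 is expected to land close to compound 1, and the step of a 1.1-fold lower number from compound 1 to compound 3 (0.06 log units; within the scatter) is expected to stay within the usual scatter or only just beyond it. In this assay compound 3 is therefore estimated at 6000 nM, with a plausible range from 2000 nM to 18000 nM.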

Compound 3, half-maximal inhibitory concentration: 10700 nM
For compound 3 the middle estimate is 1.8-fold (0.25 log units) below the measured one, within the range that was stated.
By their numbers in this assay, from the lowest: compounds 1 and 3 (each within the scatter of the next); then compound 2.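

In this assay, trifluoromethyl in place of fluoro on this aromatic carbon gives a 1.6-fold higher number from compound 1 to compound 3 (0.19 log units; within the scatter), so compound 1 and compound 3 stand level within the scatter. Going by these compounds alone, this is the first step here that can be read at a single place, and it shows that going from 3-fluorophenyl to 3-(trifluoromethyl)phenyl, with 4 heavy atoms entering where 1 leaves, does not move the number beyond the scatter on the core of compound 1. Nothing measured alongside these values offers an explanation of this result.

As far as these compounds go, whether a group of another kind on this carbon, such as an amine, a carboxylic acid or a nitrile, would give a number beyond the scatter from that of compound 1 remains open. From the compounds shown here alone, compound 2 differs from compound 1 in several places at once, and which of those differences goes with its markedly higher number also remains open.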